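A few compounds are considered here, and "the series" means these few. Any claim that something is new, unique, unknown or untested is made for them only; others in the source may bear on it.

The study compares three compounds that share one core and differ only in the group carried on an aromatic nitrogen. Compound 1 `Cc1[nH]n(-c2ccc(I)cc2)c(=O)c1/N=N/c1c(O)cc(S(=O)(=O)O)c2ccccc12` carries a 4-iodophenyl there. In an assay on BaF3 cells with thrombopoietin receptor (Homo sapiens) as the target, read by a luciferase reporter (a lower number here means a smaller maximal response, a higher number a larger maximal response), compound 1 gives 81%. Compound 2 `Cc1[nH]n(-c2cc(S(=O)(=O)O)ccc2Cl)c(=O)c1/N=N/c1c(O)cc(S(=O)(=O)O)c2ccccc12` carries a 2-chloro-5-sulfophenyl instead. In this assay compound 2 gives < 5%, which is a limit of the assay and not a number. Compound 2 thus stands at the limit of < 5% in this assay, at which 1 of the 2 values shown sits, so its position is known only as a range at the low end. Among the measured compounds shown here, the single measured step, a number at least 76 percentage points lower from compound 1 to compound 2 (beyond the scatter), shows that this exchange of the group on the aromatic nitrogen removed nearly all of the maximal response. Compound 3 `Cc1[nH]n(-c2cc(Cl)c(S(=O)(=O)O)cc2Cl)c(=O)c1/N=N/c1c(O)cc(S(=O)(=O)O)c2ccccc12` is the next step from compound 2: a group of 12 heavy atoms (6 carbon, 3 oxygen, 1 sulfur, 2 chlorine; one six-membered aromatic ring of carbon only) in place of a group of 11 heavy atoms (6 carbon, 3 oxygen, 1 sulfur, 1 chlorine; one six-membered aromatic ring of carbon only), on an aromatic nitrogen. For the measured compounds named here, the entering group differs from the leaving one only in chlorine, as the counts show, so the step from compound 1 to compound 2 is the only guide, and it points to a compound that remains near the limit. Compound 3 is therefore expected to give about 5% in this assay, within 0% to 20%. The expected step of a number no lower from compound 2 to compound 3 (the limit leaves the size open) is estimated to lie within the scatter.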

Compound 3, largest response reached (reported as efficacy), in percent of the reference or control that the assay uses: < 5%
Compound 3: only a limit was reported; the forecaster's own chance of this, stated with the estimate: 60%; the middle value lies on the limit itself.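

The added chlorine brings no response back into view, as compound 3, like compound 2, is reported only as a limit of the assay, so two different groups on the aromatic nitrogen now share the low end of this assay: the limit of < 5% in this assay, at which 2 of the 3 values shown sit.

The large loss is thus not peculiar to the 2-chloro-5-sulfophenyl group, for the exchange of the 4-iodophenyl for the new group gives a number at least 76 percentage points lower from compound 1 to compound 3 (beyond the scatter). The step between the two limits cannot be read, so nothing can be said about whether the added chlorine changes the response within that low range.

The compounds shown leave open which part of the entering groups goes with the loss, the sulfonic acid or the chlorine, since both of these groups carry both and the 4-iodophenyl of compound 1 carries neither. From the compounds shown here alone, it also remains open whether a phenyl bearing chlorine alone, or a carboxylic acid in place of the sulfonic acid, would keep the response of compound 1.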